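Triazole carboxamide aryl variations: cytotoxicity on gastric cells

This account rests on a few compounds, and the source may have more. Where it says the series, first, only, none or still open, it means among the compounds named here.

Compound 1 `COc1cc2c(Oc3ccc(NC(=O)c4nnn(-c5ccc(F)cc5)c4C(F)(F)F)cc3F)ccnc2cc1OCCCN1CCC(C)CC1`: 70 nM
Compound 2 `COc1cc2c(Oc3ccc(NC(=O)c4nnn(-c5ccc(C)cc5)c4C(F)(F)F)cc3F)ccnc2cc1OCCCN1CCC(C)CC1`: 140 nM

Going by the values given here, in a functional assay on MKN-45 cells (Homo sapiens) for cytotoxicity, read by MTT assay, with a stated time of 72 h (a higher number here means a weaker inhibitor, a lower number a stronger inhibitor), compound 2 gives 140 nM, and in this assay compound 1 gives 70 nM; the only step so far, a 2.0-fold higher number from compound 1 to compound 2 (0.30 log units; within the scatter), separates them by no more than the scatter, so compound 2 stands alongside compound 1 rather than apart from it. Compound 3 `COc1cc2c(Oc3ccc(NC(=O)c4nnn(-c5ccc(F)c(F)c5)c4C(F)(F)F)cc3F)ccnc2cc1OCCCN1CCC(C)CC1` differs from compound 2 by 3,4-difluorophenyl in place of 4-methylphenyl on an aromatic nitrogen. Among the compounds with values here, the one step in hand bears on this directly: it shows that exchanging fluoro and methyl on this aryl ring moved this assay little. Compound 3 restores a fluoro to the ring and adds a second; the expected step of a 1.8-fold lower number from compound 2 to compound 3 (0.24 log units; within the scatter) is small, toward a lower number if anything. Compound 3 is therefore estimated at 80 nM, range 35 nM to 180 nM.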

Compound 3, half-maximal inhibitory concentration: 50 nM
Beside the measured number, compound 3's estimate is 1.6-fold (0.20 log units) above it, and the stated range covers the measured number.
By their numbers in this assay, from the lowest: compounds 3, 1 and 2 (each within the scatter of the next, the first and the last beyond it).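

In this assay, going by these compounds alone, 3,4-difluorophenyl in place of 4-methylphenyl on the aromatic nitrogen gives a 2.8-fold lower number from compound 2 to compound 3 (0.45 log units; beyond the scatter) and is the first step beyond the scatter. Fluoro in place of hydrogen on the same aryl ring gives a 1.4-fold lower number from compound 1 to compound 3 (0.15 log units; within the scatter) so compound 3 is not separated from the monofluorinated compound 1. No evidence in hand bears on the cause of this result.

Open, on these data alone, is whether an amine or a carboxylic acid on this aryl ring would keep the number alongside compound 1 and compound 3.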